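A few compounds are considered here, and "the series" means these few. Any claim that something is new, unique, unknown or untested is made for them only; others in the source may bear on it.

Working notes on the series. Of the compounds shown here, three have been measured so far. Compound 1 `Nc1nc(Cl)c2ncn(Cc3ccc(CCl)cc3)c2n1` carries an amino group where compound 3 `ClCc1ccc(Cn2cnc3c(Cl)nc(Cl)nc32)cc1` carries a chloro group; compound 2 `ClCc1cccc(Cn2cnc3c(Cl)nc(Cl)nc32)c1` is built from the same atoms as compound 3, joined differently, and the difference between the two cores is not broken down here. In a functional assay on SF-539 cells (Homo sapiens) for cytotoxicity, read by sulforhodamine B assay, with a stated time of 48 h (on this read-out lower numbers stand for higher toxicity in this test and higher numbers for lower toxicity in this test), compound 1 gives 46800 nM, compound 2 gives 40700 nM and compound 3 gives 56200 nM. All three numbers lie within the usual scatter of one another, so no order among them can be read from these data.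

For the measured compounds named here, the one change seen within the measured set is amino in place of chloro on an aromatic carbon, and the step it made, a 1.2-fold lower number from compound 3 to compound 1 (0.08 log units; within the scatter), is too small to count as a real difference.

Compound 4 `Nc1nc(Cl)c2ncn(Cc3cccc(CCl)c3)c2n1` has not yet been measured. Relative to compound 2 it shows (amino in place of chloro on an aromatic carbon); the place of the change is the same, word for word, as for the step from compound 3 to compound 1, so it is the same change made on the other core. Resting on the earlier step, the step of a 1.1-fold lower number from compound 2 to compound 4 (0.05 log units; within the scatter) is expected to be small and within the scatter, since a 1.2-fold lower number from compound 3 to compound 1 (0.08 log units; within the scatter) was itself within the scatter. Compound 4 is therefore estimated at about 36000 nM in this assay. Given the scatter of this measurement, compound 4 is expected to fall between 20000 nM and 65000 nM. How the measured value compares is noted below.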

Compound 4, concentration lethal to 50% of the cells: 69200 nM
The estimate for compound 4 lay 1.9-fold (0.28 log units) below the measured number, and the stated range ends below it.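

Amino in place of chloro on an aromatic carbon, the change placed between two ring nitrogen atoms, was now read on a second core in this assay, where it gives a 1.7-fold higher number from compound 2 to compound 4 (0.23 log units; within the scatter). Set beside the earlier step, this one shows no difference between the two cores that exceeds the scatter: the same change on two cores in this assay, a 1.2-fold lower number (0.08 log units; within the scatter) from compound 3 to compound 1 and a 1.7-fold higher number (0.23 log units; within the scatter) from compound 2 to compound 4, 2.0-fold (0.31 log units) apart, within the scatter of two such steps. The change can therefore be carried between these two cores without any step beyond the scatter appearing, but neither step is a real difference on its own, so the opposite directions of the two numbers carry no meaning, and the data show neither that the change is without effect in general nor that the same would hold on any further core.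

The compounds shown leave open whether any replacement on that aromatic carbon can shift the number beyond the scatter, for instance a methoxy group, a dimethylamino group or a longer amine in place of the amino group. They also leave open whether a group other than chloro at the second position, such as a methyl group, would behave the same way when paired with the amino group on either core.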